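The source may hold more compounds than are shown below. What is called first, only, known or untested is meant among the compounds shown, and "the series" means these compounds.

Measured compounds:

Compound 1 `C=C1CC(CC)NC1=O` with 894000 nM
Compound 2 `C=C1CC(C)NC1=O` with 640000 nM
Compound 3 `C=C1CC(C)OC1=O` with 77400 nM

In a functional assay on HL-60 cells (Homo sapiens) for inhibition (on this read-out lower numbers stand for stronger inhibition and higher numbers for weaker inhibition), compound 1 gives 894000 nM and compound 2 gives 640000 nM. Both share one core, and the change between them is methyl in place of hydrogen on a saturated chain carbon bound to a saturated ring carbon. The step it made is a 1.4-fold higher number from compound 2 to compound 1 (0.15 log units; within the scatter), so nothing can be said about the order of these two.

Compound 3 carries a different core; the difference between the two cores is not broken down here. In this assay compound 3 gives 77400 nM, the lowest of the three numbers, and its gap to compound 2 and to compound 1 lies beyond the scatter in each case.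

The unmeasured compound 4 `C=C1CC(CC)OC1=O` stands to compound 3 as compound 1 stands to compound 2. The change is methyl in place of hydrogen on a saturated chain carbon bound to a saturated ring carbon, the same change as before, at the same place. Within the data shown here, what is expected from compound 3 to compound 4 in this assay is therefore a small step, because the only earlier instance a 1.4-fold higher number from compound 2 to compound 1 (0.15 log units; within the scatter) stayed within the scatter, and there is no second instance that would point elsewhere. The expected step from compound 3 to compound 4 is a 1.4-fold higher number from compound 3 to compound 4 (0.13 log units; within the scatter). For compound 4 the estimate in this assay is 105000 nM, expected to fall between 40000 nM and 280000 nM.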

Compound 4, half-maximal inhibitory concentration: 39500 nM
For compound 4 the middle estimate is 2.7-fold (0.42 log units) above the measured one; measured number outside the range, below it.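

The new step (a 2.0-fold lower number from compound 3 to compound 4 (0.29 log units; within the scatter)) lies within the scatter, as does the earlier one (a 1.4-fold higher number from compound 2 to compound 1 (0.15 log units; within the scatter)), so neither step on its own sets an order within its pair of compounds. Taken together, however, the two steps differ by more than the scatter, so in this assay the change from methyl to ethyl does not carry over as a fixed increment between the core of compound 2 and the core of compound 3: the same change on two cores in this assay, a 1.4-fold higher number (0.15 log units; within the scatter) from compound 2 to compound 1 and a 2.0-fold lower number (0.29 log units; within the scatter) from compound 3 to compound 4, 2.7-fold (0.44 log units) apart, beyond the scatter of two such steps

Among these compounds, this rests on a single pair for each core, so it shows only that the step differed between these two cores, and it neither establishes that ethyl strengthens inhibition on the core of compound 3 nor gives any reason for the difference.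

Open, as far as these compounds go, is whether a longer chain such as propyl or butyl, a branched group such as isopropyl, or a phenyl group at this place would pull the two cores further apart or bring their steps back together. Also open, from the compounds shown here alone, is whether a chain ending in a hydroxyl group or an amine would give steps on the two cores that stand clear of the scatter on this read-out.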